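The source may hold more compounds than are shown below. What is called first, only, known or untested is meant among the compounds shown, and "the series" means these compounds.

The shared core is kept throughout; compound 1 `COc1cc(C2=NN(C(C)=O)C(c3ccccc3C(F)(F)F)O2)cc(OC)c1OC`, compound 2 `COc1cc(C2=NN(C(C)=O)C(c3ccc(Cl)c(Cl)c3)O2)cc(OC)c1OC` and compound 3 `COc1cc(C2=NN(C(C)=O)C(c3ccc(Cl)c([N+](=O)[O-])c3)O2)cc(OC)c1OC` differ only in the aryl group on the saturated ring carbon. In a functional assay on PC-3 cells (Homo sapiens) for antiproliferative activity, read by MTT assay, tested at 1 uM (on this read-out higher numbers stand for a stronger effect at the one concentration tested and lower numbers for a weaker effect), compound 1 gives -11%, compound 2 gives 28.1% and compound 3 gives 43.3%. Compound 3 stands highest of the three numbers, with compound 2 nearest and compound 1 furthest, both gaps beyond the scatter. The steps run a number 39.1 percentage points higher from compound 1 to compound 2 (beyond the scatter), a number 54.3 percentage points higher from compound 1 to compound 3 (beyond the scatter) and a number 15.2 percentage points higher from compound 2 to compound 3 (beyond the scatter).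

Compound 4 `COc1cc(C2=NN(C(C)=O)C(c3cccc(C(F)(F)F)c3)O2)cc(OC)c1OC` differs from compound 3 in one place: 3-(trifluoromethyl)phenyl in place of 4-chloro-3-nitrophenyl on a saturated ring carbon. All three measured steps bear on this, as compound 1 also carries a trifluoromethyl-bearing ring, and the large gains came with the chloro- and nitro-bearing rings, while the nitro-for-chloro exchange alone was modest. Returning to a trifluoromethyl-bearing ring is expected to give back a large part of that gain, in the downward direction, because compound 1 sits at -11%; the different position of the group leaves some room above that. The expected step is a number 33.3 percentage points lower from compound 3 to compound 4 (beyond the scatter). Compound 4 is estimated at 10%, within -15% to 35%.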

Compound 4, a percentage reported as inhibition, at one concentration (the size of the read-out at that concentration, not a potency): 30.1%
The estimate for compound 4 lay 20.1 percentage points below the measured number; low and high end bracket the measured number.
By their numbers in this assay, from the lowest: compound 1; then compounds 2 and 4 (each within the scatter of the next); then compound 3.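

In this assay the trifluoromethyl group does not by itself bring the low number, as the change from 2-(trifluoromethyl)phenyl to 3-(trifluoromethyl)phenyl on the saturated ring carbon gives a number 41.1 percentage points higher from compound 1 to compound 4 (beyond the scatter) with the same group on both rings. Among the four rings, 4-chloro-3-nitrophenyl stays on top: the series shows a number 13.2 percentage points lower from compound 3 to compound 4 (beyond the scatter) on going to 3-(trifluoromethyl)phenyl, and a number 2 percentage points higher from compound 2 to compound 4 (within the scatter) when that ring replaces 3,4-dichlorophenyl. Nothing at hand explains why the two trifluoromethyl-bearing rings part so widely.

On these data alone, whether an aryl ring carrying an amine or a carboxylic acid would keep the number at this carbon remains open, as does the outcome with a longer alkyl chain in place of the aryl group. All of these numbers come from one concentration, so they leave potency open.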